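Swapping one aromatic group for another on the amide

The source may report more compounds than this note shows. Statements on the series, on what has been measured and on what is new or still open speak of the compounds shown alone.

Of the compounds shown here, two sharing the same core have been measured in a functional assay (Sus scrofa) with sulfonylurea receptors; K-ATP channels (Homo sapiens) as the target; on this read-out lower numbers stand for an effect already at smaller amounts and higher numbers for an effect only at larger amounts of compound. Compound 1 `O=C(Nc1c(C(O)(C(F)(F)F)C(F)(F)F)ccc2ccccc12)C1CCC1` gives 81.3 nM in this assay. Within the data shown here, compound 2 `N#Cc1cccc(C(=O)Nc2c(C(O)(C(F)(F)F)C(F)(F)F)ccc3ccccc23)c1` gives 372 nM in this assay, the higher of the two numbers, with compound 1 as its only neighbour. Among the measured compounds shown here, the single measured step is a 4.6-fold higher number from compound 1 to compound 2 (0.66 log units; beyond the scatter).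

Compound 3 `O=C(Nc1c(C(O)(C(F)(F)F)C(F)(F)F)ccc2ccccc12)c1ccc(Cl)cc1` has not yet been measured. It differs from compound 2 by 4-chlorophenyl in place of 3-cyanophenyl on a carbonyl carbon. For the measured compounds named here, no measured step exchanges one aromatic group for another on this carbonyl carbon, so the one step available shows only that the group on the carbonyl carbon can matter, not how two aromatic groups compare with each other.

For compound 3 the value expected in this assay is 250 nM, with a range from 80 nM to 800 nM. This estimate means an expected step of a 1.5-fold lower number from compound 2 to compound 3 (0.17 log units; within the scatter), a change that is expected to be small, if any.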

Compound 3, half-maximal effective concentration: 389 nM
Compound 3: the middle estimate sits 1.6-fold (0.19 log units) below what was measured, within the range that was stated.
By their numbers in this assay, from the lowest: compound 1; then compounds 2 and 3 (each within the scatter of the next).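

In this assay, putting 4-chlorophenyl in place of 3-cyanophenyl on the carbonyl carbon gives a 1.0-fold higher number from compound 2 to compound 3 (0.02 log units; within the scatter), so these two aromatic groups cannot be told apart at this position. The comparison with cyclobutyl now rests on two aromatic groups: a 4.8-fold higher number from compound 1 to compound 3 (0.68 log units; beyond the scatter) is close in size to a 4.6-fold higher number from compound 1 to compound 2 (0.66 log units; beyond the scatter), and both aromatic compounds carry higher numbers than the cyclobutyl compound. Nothing available explains why the numbers fall this way.

On these data alone, whether an unsubstituted phenyl or a pyridine ring would give a similar number remains open. So does whether the lower number is particular to cyclobutyl or would also appear with cyclopropyl, cyclohexyl or an open chain such as isobutyl.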